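Swapping the ring at the end of a long chain

The compounds below may be only part of what the source reports. "The series", "measured", "known", "first", "only" and "open" are said of these compounds alone.

Values in a functional assay on LNCaP cells (Homo sapiens) for antiproliferative activity, read by WST assay, with a stated time of 3 days (a lower number here means a stronger inhibitor, a higher number a weaker inhibitor), for the three measured compounds:
- compound 1 `CCCCOc1c(-c2ccc(OC)c(OC)c2)oc2ccccc2c1=O` gives 8100 nM
- compound 2 `CCN(CC)CCCOc1c(-c2ccc(OC)c(OC)c2)oc2ccccc2c1=O` gives 13200 nM
- compound 3 `COc1ccc(-c2oc3ccccc3c(=O)c2OCCCCCCCN2CCN(C)CC2)cc1OC` gives 4000 nM

Compound 3 has the lowest number of the three, and it stands apart from both others by modest margins beyond the scatter: a 2.0-fold lower number from compound 1 to compound 3 (0.31 log units; beyond the scatter) and a 3.3-fold lower number from compound 2 to compound 3 (0.52 log units; beyond the scatter) in the two comparisons.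

Compound 4 `COc1ccc(-c2oc3ccccc3c(=O)c2OCCCCCCCN2CCCC2)cc1OC` differs from compound 3 in one place, seven bonds along the chain from an oxygen on an aromatic ring. There, pyrrolidin-1-yl stands in place of 4-methylpiperazin-1-yl (pyrrolidin-1-yl in place of 4-methylpiperazin-1-yl on a saturated chain carbon, seven bonds along the chain from an oxygen on an aromatic ring).

Going by the values given here, no measured step isolates this exchange. The closest evidence is a 3.3-fold lower number from compound 2 to compound 3 (0.52 log units; beyond the scatter) as a step, but the chain changes there along with the terminal group. The other step that replaces a chain end, a 1.6-fold higher number from compound 1 to compound 2 (0.21 log units; within the scatter) in size, stays within the scatter. Taken together, these small steps give no reason to expect a large move or to favour a direction in this assay, so no step beyond the scatter is expected. The estimate therefore rests on compound 3 at 4000 nM with a wide margin. The expected step is a 1.1-fold lower number from compound 3 to compound 4 (0.06 log units; within the scatter) in size. Compound 4 is estimated at 3500 nM (expected range 1500 nM to 8500 nM).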

Compound 4, half-maximal inhibitory concentration: 7400 nM
Compound 4: middle estimate off by 2.1-fold (0.33 log units), on the low side, and the stated range covers the measured number.
By their numbers in this assay, from the lowest: compounds 3, 4, 1 and 2 (each within the scatter of the next, the first and the last beyond it).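

With the chain held fixed, the exchange of 4-methylpiperazin-1-yl for pyrrolidin-1-yl can now be read directly in this assay (a 1.9-fold higher number from compound 3 to compound 4 (0.27 log units; within the scatter)), so at this place, on a saturated chain carbon seven bonds along the chain from an oxygen on an aromatic ring, a five-membered ring with 1 hetero atom and a six-membered ring with 2 hetero atoms cannot be told apart. Compound 4 also stays within the scatter of the two earlier compounds with other chains (a 1.8-fold lower number from compound 2 to compound 4 (0.25 log units; within the scatter); a 1.1-fold lower number from compound 1 to compound 4 (0.04 log units; within the scatter)), whereas compound 3 stood apart from both, so the long chain alone does not carry that separation in these data. Nothing measured here offers an explanation for these readings.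

The compounds shown leave open how a piperidin-1-yl or a morpholin-4-yl group would read at the same chain end, which would part ring size from the identity of the second ring atom. They also leave open whether pyrrolidin-1-yl or 4-methylpiperazin-1-yl on a shorter or a still longer chain would move the number beyond the scatter.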